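The source may report more compounds than this note shows. Statements on the series, on what has been measured and on what is new or still open speak of the compounds shown alone.

Working notes on the series. In a functional assay on K562 cells (Homo sapiens) for antiproliferative activity, read by CellTiter-Glo and CCK-8 assay, with a stated time of 72 h (a higher number here means a weaker inhibitor of growth, a lower number a stronger inhibitor of growth), compound 1 `CNc1nc(Nc2ccc(C)c([N+](=O)[O-])c2)ncc1C(=O)Nc1cc(NC(=O)c2cccc(C(F)(F)F)c2)ccc1C` gives 52 nM. Compound 2 `CNc1nc(Nc2ccc(C)c([N+](=O)[O-])c2)ncc1C(=O)Nc1cc(NC(=O)c2ccccc2OC)ccc1C` returns only a limit of the assay, > 10000 nM. Compound 3 `CNc1nc(Nc2ccc(C)c([N+](=O)[O-])c2)ncc1C(=O)Nc1cc(NC(=O)c2cc(OC)cc(OC)c2)ccc1C` gives 1070 nM in this assay. Among the two real numbers compound 3 stands highest; its nearest neighbour is compound 1, with a 21-fold higher number from compound 1 to compound 3 (1.31 log units; beyond the scatter). The other steps are an at least 190-fold higher number from compound 1 to compound 2 (2.28 log units; beyond the scatter) and an at least 9.3-fold lower number from compound 2 to compound 3 (0.97 log units; beyond the scatter); one of the three results sits at the limit of > 10000 nM in this assay, at which 1 of the 3 values shown sits.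

Compound 4 `CNc1nc(Nc2ccc(C)c([N+](=O)[O-])c2)ncc1C(=O)Nc1cc(NC(=O)c2ccc3c(c2)OCCO3)ccc1C` carries 2,3-dihydro-1,4-benzodioxin-6-yl in place of 3,5-dimethoxyphenyl on a carbonyl carbon. All three measured steps concern the aryl group on this carbonyl carbon, and every such exchange moved the number beyond the scatter, in either direction. Going by the values given here, the closest precedent is compound 3 itself, whose two oxygen acceptors on the aryl ring are kept; the change is expected to shift this assay only a little, and the estimate is a 1.4-fold higher number from compound 3 to compound 4 (0.15 log units; within the scatter). Compound 4 is therefore expected at about 1500 nM, between 300 nM and 8000 nM.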

Compound 4, concentration for 50% growth inhibition: 320 nM
For compound 4 the middle estimate is 4.7-fold (0.67 log units) above the measured one; low and high end bracket the measured number.
By their numbers in this assay, from the lowest: compound 1; then compound 4; then compound 3. At a limit, above all of these: compound 2.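

In this assay, the 3,5-dimethoxyphenyl and 2,3-dihydro-1,4-benzodioxin-6-yl groups have the same number of heavy atoms, oxygen atoms and hydrogen-bond acceptors, yet the exchange gives a 3.3-fold lower number from compound 3 to compound 4 (0.52 log units; beyond the scatter), so this position separates aryl groups even when those counts stay unchanged. The oxygen-bearing group of compound 4 still falls short of the 3-(trifluoromethyl)phenyl group, with a 6.2-fold higher number from compound 1 to compound 4 (0.79 log units; beyond the scatter). The remaining step is an at least 31-fold lower number from compound 2 to compound 4 (1.49 log units; beyond the scatter), and it is read against a limit of the assay, not a number: the limit of > 10000 nM in this assay, at which 1 of the 4 values shown sits.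

On these data alone, whether the lower number belongs to the six-membered non-aromatic ring itself or to the placing of its oxygen atoms on the aryl ring stays open. Also open, as far as these compounds go, is how an aryl group carrying a nitrile or a dimethylamino group would read in this assay.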